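A heteroaromatic ring replaces methoxyphenyl on the exocyclic carbon

The source may hold more compounds than are shown below. What is called first, only, known or untested is meant among the compounds shown, and "the series" means these compounds.

Measured compounds:
compound 1 `CCOC(=O)C1=C(Nc2ccccc2)S/C(=C\c2ccc(OC)cc2)C1=O` gives 32.9%
compound 2 `CCOC(=O)C1=C(Nc2ccc(F)cc2)S/C(=C\c2ccc[nH]2)C1=O` gives 61.5%

In a functional assay on JAR cells (Homo sapiens) for inhibition, read by MTT assay, with a stated time of 72 h, tested at 10 uM (a higher number here means more inhibition at the concentration tested (going by the name of the read-out), a lower number less inhibition), compound 1 stands lowest of the two numbers; compound 2 lies higher by an amount beyond the usual scatter. Compound 3 `CCOC(=O)C1=C(Nc2ccccc2)S/C(=C\c2cc3ncccc3[nH]2)C1=O` differs from compound 1 in one place: a group of 9 heavy atoms (7 carbon, 2 nitrogen; one five-membered aromatic ring with 1 hetero atom, one six-membered aromatic ring with 1 hetero atom) in place of a group of 8 heavy atoms (7 carbon, 1 oxygen; one six-membered aromatic ring of carbon only), on a double-bonded chain carbon bound to a double-bonded ring carbon. Among the measured compounds shown here, no comparable step has been measured, so the expectation rests on compound 2, whose value of 61.5% in this assay suggests that a ring carrying a hydrogen-bond donor at this position can go with more inhibition. For compound 3 a rise of roughly a number 22.1 percentage points higher from compound 1 to compound 3 (beyond the scatter) is therefore expected. Compound 3 is estimated at 55%, within 30% to 80%.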

Compound 3, a percentage reported as inhibition, at one concentration (the size of the read-out at that concentration, not a potency): 74.8%
The estimate for compound 3 lay 19.8 percentage points below the measured number; low and high end bracket the measured number.
By their numbers in this assay, from the lowest: compound 1; then compound 2; then compound 3.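

In this assay the swap of 4-methoxyphenyl for the two-ring group gives a number 41.9 percentage points higher from compound 1 to compound 3 (beyond the scatter) with the rest of the molecule unchanged. Among the compounds shown here, this is the first direct sign that the group at this place alone can shift the read-out by a large amount. The entering group carries a hydrogen-bond donor and the leaving group none, but nothing measured here links that difference to the rise.

As far as these compounds go, whether an indole group, whose six-membered ring is carbon only, would match this result stays open. So does the effect of a phenyl ring carrying an amine at the same place.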